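Aryl swap on the oxalamide: cytotoxicity outlook for compound 4

The source may report more compounds than this note shows. Statements on the series, on what has been measured and on what is new or still open speak of the compounds shown alone.

The series shares a core carrying a hydroxyalkyl-substituted thiazole and an oxalamide link to an aryl ring. Compound 3 `Cc1nc(C(NC(=O)C(=O)Nc2ccc(Cl)c(F)c2)C2CCCCN2)sc1CCO` gives 61000 nM in an ADME assay on TZM-b1 cells (Homo sapiens) for cytotoxicity, read by XTT assay, with a stated time of 3 days; on this read-out higher numbers stand for lower toxicity in this test and lower numbers for higher toxicity in this test. Compound 1 `Cc1nc(C(NC(=O)C(=O)Nc2ccc(Cl)c(F)c2)C2CCCCN2)sc1CO` gives 58400 nM in this assay. Compound 2 `Cc1ccc(NC(=O)C(=O)NC(c2nc(C)c(CO)s2)C2CCCCN2)cc1F` reaches only a limit of the assay, > 88000 nM, in this assay. Two measured steps exist: a 1.0-fold higher number from compound 1 to compound 3 (0.02 log units; within the scatter) and an at least 1.5-fold higher number from compound 1 to compound 2 (0.17 log units; that floor lies within the scatter); only the second bears on the aryl ring, and it reaches the limit of > 88000 nM in this assay, at which 1 of the 3 values shown sits, rather than a number. Among the numbers shown, compound 3 sits highest, with compound 1 within the scatter of it.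

Compound 4 `Cc1nc(C(NC(=O)C(=O)Nc2ccc(F)cc2F)C2CCCCN2)sc1CCO` differs from compound 3 by 2,4-difluorophenyl in place of 4-chloro-3-fluorophenyl on an amide-type nitrogen. The one aryl step shown, from compound 1 to compound 2, gave at most a small rise that is itself within the scatter, so for compound 4 no step beyond the scatter is expected, with a slight lean upward; the expected step is a 1.1-fold higher number from compound 3 to compound 4 (0.06 log units; within the scatter). Compound 4 is therefore estimated at 70000 nM, within 35000 nM to 140000 nM in this assay.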

Compound 4, half-maximal cytotoxic concentration: > 84000 nM
Compound 4 gave a limit, no number; the forecaster's own chance of this, stated with the estimate: 35%; middle value at least 1.2-fold (0.07 log units) away from the limit.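

Compound 4 ends at a limit of the assay, not a number, so the aryl ring on the amide-type nitrogen has now reached a limit with the longer hydroxyalkyl chain on the thiazole: the limit of > 84000 nM in this assay, at which 1 of the 4 values shown sits.
Compound 2, with the shorter hydroxymethyl chain and also without the chloro group, likewise ends at a limit: the limit of > 88000 nM in this assay, at which 1 of the 4 values shown sits.
In this assay the change to 2,4-difluorophenyl gives an at least 1.3-fold higher number from compound 3 to compound 4 (0.13 log units; that floor lies within the scatter), so it fixes only a floor, and that floor does not show an effect of this aryl swap.

On these data alone, the true size of the step remains open, as does whether losing the chloro group or placing the two fluorines accounts for the limit in compound 4. As far as these compounds go, how an amine or a carboxylic acid on this aryl ring would read in this assay also stays open.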